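Fluorine on the Benzyl Group in Three Pyrazole Carboxamides

A few compounds are considered here, and "the series" means these few. Any claim that something is new, unique, unknown or untested is made for them only; others in the source may bear on it.

Measured compounds:
Compound 1 `COc1ccc(-c2nn(-c3ccccc3)cc2C(=O)NOCc2ccccc2)cc1`: 2770 nM
Compound 2 `COc1ccc(-c2nn(-c3ccccc3)cc2C(=O)NOCc2ccccc2F)cc1`: 6000 nM
Compound 3 `O=C(NOCc1ccccc1)c1cn(-c2ccccc2)nc1-c1ccc(F)cc1`: 15300 nM

The three measured compounds were tested in a functional assay on MCF7 cells (Homo sapiens) for antiproliferative activity, read by MTT assay, with a stated time of 48 h, in the presence of a further agent that is not named here; a higher number here means a weaker inhibitor of growth, a lower number a stronger inhibitor of growth. Compound 1 gives 2770 nM in this assay, the lowest of the three numbers. Compound 2 differs from compound 1 by fluoro in place of hydrogen on an aromatic carbon, and this change gave a 2.2-fold higher number from compound 1 to compound 2 (0.34 log units; beyond the scatter). Compound 3 differs from compound 1 in its core by fluoro in place of methoxy on an aromatic carbon, and this gave a 5.5-fold higher number from compound 1 to compound 3 (0.74 log units; beyond the scatter), so that compound 3 stands highest of the three.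

Compound 4 `O=C(NOCc1ccccc1F)c1cn(-c2ccccc2)nc1-c1ccc(F)cc1` has not been measured in this assay. It differs from compound 3 by fluoro in place of hydrogen on an aromatic carbon. This is the same change as from compound 1 to compound 2, and the place of the change reads the same in both cases. The two cores differ by fluoro in place of methoxy on an aromatic carbon.

Within the data shown here, since only one earlier example of this change is available, the expectation for compound 4 rests on the step of a 2.2-fold higher number from compound 1 to compound 2 (0.34 log units; beyond the scatter), carried over to the core of compound 3. On that basis compound 4 is expected to give a higher number than compound 3, a step estimated as a 2.0-fold higher number from compound 3 to compound 4 (0.29 log units; within the scatter). Compound 4 is thus estimated at 30000 nM, with a plausible range from 12000 nM to 75000 nM.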

Compound 4, concentration for 50% growth inhibition: 12000 nM
Compound 4: middle estimate off by 2.5-fold (0.40 log units), on the high side, within the range that was stated.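

In this assay, benzyl to 2-fluorobenzyl on the core carrying the second fluoro gave a 1.3-fold lower number from compound 3 to compound 4 (0.11 log units; within the scatter), so the step seen with the methoxy core did not carry over: the same change on two cores in this assay, a 2.2-fold higher number (0.34 log units; beyond the scatter) from compound 1 to compound 2 and a 1.3-fold lower number (0.11 log units; within the scatter) from compound 3 to compound 4, 2.8-fold (0.44 log units) apart, beyond the scatter of two such steps Read the other way, fluoro in place of methoxy gave a 2.0-fold higher number from compound 2 to compound 4 (0.30 log units; within the scatter) among the 2-fluorobenzyl compounds, a smaller step than among the benzyl compounds: the same change on two cores in this assay, a 5.5-fold higher number (0.74 log units; beyond the scatter) from compound 1 to compound 3 and a 2.0-fold higher number (0.30 log units; within the scatter) from compound 2 to compound 4, 2.8-fold (0.44 log units) apart, beyond the scatter of two such steps These four compounds thus show that the result of the benzyl change depended on the core and that the two changes did not simply add, but they do not show why, and with a single pair on each core they establish no rule for the wider series.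

The compounds shown leave open whether a chloro or a methyl group in place of the benzyl fluoro would also give steps that differ between the two cores. They also leave open how a core with a hydroxyl or an amine in place of the methoxy would respond to the same benzyl change.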